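The source may report more compounds than this note shows. Statements on the series, on what has been measured and on what is new or still open speak of the compounds shown alone.

Values in a functional assay on QGY-7703 cells (Homo sapiens) for cytotoxicity, read by MTT assay, with a stated time of 24 h; a higher number here means a weaker inhibitor, a lower number a stronger inhibitor:
- compound 1 `CN1C/C(=C\c2cccnc2)C(=O)/C(=C/c2ccccc2C(F)(F)F)C1`: 2910 nM
- compound 2 `O=C1/C(=C/c2cccnc2)CN(S(=O)(=O)c2ccc(C(F)(F)F)cc2)C/C1=C\c1ccccc1F`: 4500 nM
- compound 3 `O=C1/C(=C/c2cccnc2)CN(S(=O)(=O)c2ccc(C(F)(F)F)cc2)C/C1=C\c1ccccc1C(F)(F)F`: 1500 nM

Compound 3 and compound 1 make up the low end of these three numbers and lie within the scatter of each other. Within the data shown here, compound 2 stands apart from compound 3, as the one measured step shows: a 3.0-fold lower number from compound 2 to compound 3 (0.48 log units; beyond the scatter).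

Compound 4 `N#Cc1ccc(S(=O)(=O)N2C/C(=C\c3cccnc3)C(=O)/C(=C/c3ccccc3C(F)(F)F)C2)cc1` follows from compound 3 by a single change: cyano in place of trifluoromethyl on an aromatic carbon. In short, cyano in place of trifluoromethyl on an aromatic carbon, read further out as 4-(trifluoromethyl)phenyl to 4-cyanophenyl.

Among the measured compounds shown here, no measured step covers this change. The modest step of a 3.0-fold lower number from compound 2 to compound 3 (0.48 log units; beyond the scatter) is a different change at a different place, so it gives only a rough sense of how far one small substitution can move the number here. No shift beyond the scatter is therefore expected, and no firm direction. The estimated step is a 1.2-fold higher number from compound 3 to compound 4 (0.08 log units; within the scatter). For compound 4 the expected value is 1800 nM, with an estimated range of 800 nM to 4000 nM.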

Compound 4, half-maximal inhibitory concentration: 6150 nM
The estimate for compound 4 lay 3.4-fold (0.53 log units) below the measured number, and the stated range ends below it.
By their numbers in this assay, from the lowest: compounds 3, 1, 2 and 4 (each within the scatter of the next, the first and the last beyond it).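

In this assay, among these compounds, the ring carried on the sulfonyl group proves a position that can move the number: 4-(trifluoromethyl)phenyl to 4-cyanophenyl gives a 4.1-fold higher number from compound 3 to compound 4 (0.61 log units; beyond the scatter), the first measured step at this place. The same group also separates from methyl on the ring amine nitrogen, with a 2.1-fold higher number from compound 1 to compound 4 (0.32 log units; beyond the scatter), whereas compound 3 at 1500 nM and compound 1 at 2910 nM lie within the scatter of each other, so the outcome of a sulfonyl group on that nitrogen depends on the substituent it carries. Nothing at hand bears on the reason for these shifts.

From the compounds shown here alone, whether trifluoromethyl and cyano are two points on a wider trend stays open, and a methoxy group, a chlorine or a carboxylic acid at this place would test that. Also open, going by these compounds, is whether the cyano step holds when the fluoro group of compound 2 replaces the trifluoromethyl on the other aromatic ring.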